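Amide Variation on a Shared Alkene Linker

The source may report more compounds than this note shows. Statements on the series, on what has been measured and on what is new or still open speak of the compounds shown alone.

Compound 1 `CNC(=O)/C=C/c1ccncc1-c1ccc2[nH]ccc2c1`: 51.9 nM
Compound 2 `O=C(O)[C@@H]1CCCN1C(=O)/C=C/c1ccncc1-c1ccc2ccccc2c1`: "not determined" (no result reported)
Compound 3 `CN1CCN(C(=O)/C=C/c2ccncc2-c2ccc(F)cc2)CC1`: 1210 nM

The three compounds share a core in which an alkene linker carries an amide. In an assay on a protein complex for inhibition of CDK8/Cyclin C (Homo sapiens), with a stated time of 1 h (on this read-out lower numbers stand for stronger inhibition and higher numbers for weaker inhibition), compound 1 gives 51.9 nM. Compound 3 gives 1210 nM in this assay. For compound 2 this assay returned "not determined" (no result reported), so no number places it on the scale; it stands only as the structural starting point for the next step.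

Compound 4 `CN(C)C(=O)/C=C/c1ccncc1-c1ccc2ccccc2c1` is not yet measured. It differs from compound 2 in one place: dimethylamino in place of 2-carboxypyrrolidin-1-yl on a carbonyl carbon. As a step between measured compounds is absent, its size in this assay cannot be read from the data. The tertiary amide of compound 3 paired with the fluorophenyl group gave 1210 nM, whereas the secondary amide of compound 1 paired with the indole gave 51.9 nM; compound 4 combines a tertiary amide with the bicyclic aryl group of compound 2, so a result somewhere between these two is expected, with wide uncertainty. Compound 4 is estimated to give 300 nM in this assay, within 60 nM to 1500 nM.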

Compound 4, half-maximal inhibitory concentration: 30.1 nM
Compound 4: the middle estimate sits 10-fold (1.00 log units) above what was measured; measured number below the stated range.
By their numbers in this assay, from the lowest: compounds 4 and 1 (each within the scatter of the next); then compound 3.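

Compound 4 gives 30.1 nM in this assay, but compound 2 has no number on this scale, so no step can be read from compound 2 to compound 4. No supporting data bear on the value of compound 4. The compounds shown leave open how changing the amide alone, with the rest of the structure held fixed, shifts the value.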